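The source may report more compounds than this note shows. Statements on the series, on what has been measured and on what is new or still open speak of the compounds shown alone.

Working notes on the series, all read in a functional assay on HEp-2 cells (Homo sapiens) for cytotoxicity; a higher number here means a weaker inhibitor, a lower number a stronger inhibitor. Compound 1 `Nc1nc(N)c2nnn([C@@H]3O[C@H](CO)[C@@H](O)[C@H]3O)c2n1` gives 700 nM. Compound 2 `CCOc1nc(N)c2nnn(C3O[C@H](CO)[C@@H](O)[C@H]3O)c2n1` is reported only as a limit, > 75000 nM. Compound 3 `CS(=O)(=O)c1nc(N)c2nn(C3O[C@H](CO)[C@@H](O)[C@H]3O)nc2n1` gives 22000 nM, the higher of the two actual numbers, and the gap to compound 1 lies beyond the scatter.

The next compound is compound 4 `Nc1nc(F)nc2nn(C3O[C@H](CO)[C@@H](O)[C@H]3O)nc12`, with fluoro in place of methylsulfonyl on an aromatic carbon, between two ring nitrogen atoms: fluoro in place of methylsulfonyl on an aromatic carbon.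

Among the compounds with values here, no measured step in this set isolates this change, so the expectation is loose. A modest move towards a lower number in this assay is expected, possibly not far beyond the scatter. Within the data shown here, the anchor is compound 3 at 22000 nM, while compound 1 at 700 nM marks the only lower number. The expected change is a 2.2-fold lower number from compound 3 to compound 4 (0.34 log units; beyond the scatter). For compound 4 the estimated value is 10000 nM, with an expected range from 2500 nM to 50000 nM.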

Compound 4, half-maximal inhibitory concentration: > 75000 nM
Compound 4 gave a limit, no number (the forecaster's own chance of this, stated with the estimate: 30%); middle value at least 7.5-fold (0.87 log units) away from the limit.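

Within the data shown here, on this aromatic carbon, between two ring nitrogen atoms, fluoro in place of methylsulfonyl gives an at least 3.4-fold higher number from compound 3 to compound 4 (0.53 log units; beyond the scatter) in this assay, the first step that isolates a single group at this place. The direction is clear: the smaller fluoro does not bring the number down, and of this pair only compound 3, with methylsulfonyl, gives an actual number, 22000 nM. Compound 4 is reported only as a limit, so the step gives a bound and not a size: the limit of > 75000 nM in this assay, at which 2 of the 4 values shown sit.

As far as these compounds go, how far compound 4 lies beyond that limit remains open, and with it the full size of the step. Also open, from the compounds shown here alone, is how a chloro group, a methylamino group or a carboxylic acid on this same carbon would compare with methylsulfonyl.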